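Swapping pyridine rings on a shared pyrazole amide core

The compounds below may be only part of what the source reports. "The series", "measured", "known", "first", "only" and "open" are said of these compounds alone.

Of the compounds shown here, three built on one shared amide core have been tested in a functional assay on WM1361 cells (Homo sapiens) for antiproliferative activity, read by MTT assay, with a stated time of 48 h; a higher number here means a weaker inhibitor, a lower number a stronger inhibitor. Compound 1 `O=C(Nc1cc(-c2ccccc2)[nH]n1)c1cccnc1Cl` gives 17300 nM in this assay. Compound 2 `O=C(Nc1cc(-c2ccccc2)[nH]n1)c1cncc(Br)c1` gives 19300 nM in this assay. Compound 3 `Cc1ccc(-c2cc(NC(=O)c3cccnc3Cl)n[nH]2)cc1` gives 15800 nM in this assay. All three numbers sit within the usual scatter of one another, so none of them can be called stronger or weaker than the others.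

Compound 2 differs from compound 1 in one place: 5-bromopyridin-3-yl in place of 2-chloropyridin-3-yl on a carbonyl carbon That change moved the number by a 1.1-fold higher number from compound 1 to compound 2 (0.05 log units; within the scatter), which is inside the scatter of repeated measurements.

Compound 4 `Cc1ccc(-c2cc(NC(=O)c3cncc(Br)c3)n[nH]2)cc1` has not yet been measured. It is related to compound 3 in the same way: 5-bromopyridin-3-yl in place of 2-chloropyridin-3-yl on a carbonyl carbon The surroundings of the change are the same in both pairs, so this is the same change made on a different core. The two cores differ by methyl in place of hydrogen on an aromatic carbon That difference gave a 1.1-fold lower number from compound 1 to compound 3 (0.04 log units; within the scatter), also inside the scatter.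

Since the same change made from compound 1 to compound 2 produced no movement beyond the scatter, the step from compound 3 to compound 4 is expected to be about as small, near a 1.1-fold higher number from compound 3 to compound 4 (0.04 log units; within the scatter). On that basis compound 4 is estimated to give around 17500 nM in this assay, most likely between 9000 nM and 35000 nM.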

Compound 4, half-maximal inhibitory concentration: 17900 nM
Compound 4: middle estimate off by 1.0-fold (0.01 log units), on the low side, and the stated range covers the measured number.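

On the core carrying the methyl, the change from 2-chloropyridin-3-yl to 5-bromopyridin-3-yl gives a 1.1-fold higher number from compound 3 to compound 4 (0.05 log units; within the scatter), and it matches what the same change did on the core of compound 1: the same change on two cores in this assay, a 1.1-fold higher number (0.05 log units; within the scatter) from compound 1 to compound 2 and a 1.1-fold higher number (0.05 log units; within the scatter) from compound 3 to compound 4, 1.0-fold (0.01 log units) apart, within the scatter of two such steps. With 5-bromopyridin-3-yl on the carbonyl carbon, methyl in place of hydrogen gives a 1.1-fold lower number from compound 2 to compound 4 (0.03 log units; within the scatter), and this also matches its earlier step: the same change on two cores in this assay, a 1.1-fold lower number (0.04 log units; within the scatter) from compound 1 to compound 3 and a 1.1-fold lower number (0.03 log units; within the scatter) from compound 2 to compound 4, 1.0-fold (0.01 log units) apart, within the scatter of two such steps. Both changes therefore carry from one core to the other in a limited sense, since neither moves the number beyond the scatter on either core, but steps this small do not show that a change with a clear effect would carry across in the same way.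

Among these compounds, every pyridine ring here carries a chlorine or a bromine and the only other change is a single methyl, so it remains open whether any change can move the number in this assay beyond the scatter. A pyridine ring bearing an amine or a carboxylic acid in place of the halogen, or a longer chain in place of the methyl, would put that question to the test.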